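This account rests on a few compounds, and the source may have more. Where it says the series, first, only, none or still open, it means among the compounds named here.

Measured in an ADME assay on microsomes from liver (Homo sapiens) for metabolic stability, with a stated time of 30 min; a higher number here means that more of the compound is left, a lower number that less of the compound is left:
- Compound 1 `COc1nc2c(cc1Nc1ccc(Cl)c(F)c1)c(=O)c(C(=O)O)cn2[C@H](CO)C(C)C`: "not determined" (no result reported)
- Compound 2 `COc1nc2c(cc1NCc1cccc(Cl)c1F)c(=O)c(C(=O)O)cn2[C@H](CO)C(C)C`: "not determined" (no result reported)
- Compound 3 `COc1nc2c(cc1NCc1ccc(F)cc1)c(=O)c(C(=O)O)cn2[C@H](CO)C(C)C`: 87%

Among the measured compounds shown here, compound 3 stands alone in this assay: at 87%, it holds the only number, since the other two entries carry no result. It therefore cannot be ranked against any measured neighbour.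

The next compound to be tested is compound 4 `COc1nc2c(cc1NCc1c(F)cc(F)cc1F)c(=O)c(C(=O)O)cn2[C@H](CO)C(C)C`. It has 2,4,6-trifluorophenyl in place of 4-fluorophenyl on a saturated chain carbon bound to a nitrogen on an aromatic ring, and the rest of the structure is unchanged: 2,4,6-trifluorophenyl in place of 4-fluorophenyl on a saturated chain carbon bound to a nitrogen on an aromatic ring.

For the measured compounds named here, no pair of measured compounds shows what a change of this kind does in this assay, so the expectation rests on compound 3 alone, and it is a loose one. With compound 3 at 87%, a step within the scatter is expected, with a slight lean downward. The expected step runs a number 3 percentage points lower from compound 3 to compound 4 (within the scatter). Compound 4 is expected at 84%, with an estimated range from 68% to 96%.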

Compound 4, percent of the compound remaining: 82%
Compound 4: middle estimate off by 2 percentage points, on the high side; low and high end bracket the measured number.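

In this assay, the series now has its first readable step at this position: 2,4,6-trifluorophenyl in place of 4-fluorophenyl on a saturated chain carbon bound to a nitrogen on an aromatic ring gives a number 5 percentage points lower from compound 3 to compound 4 (within the scatter), so the two compounds cannot be told apart in this read-out. Compound 3 no longer stands alone, and this position accepts 2,4,6-trifluorobenzyl as well as 4-fluorobenzyl with compound 4 at 82%, a value that remains close to that of its neighbour. Nothing on hand explains this outcome, and no cause can be assigned to it.

A single pair cannot show whether this holds for other substituents, so a benzyl ring carrying a methoxy group or a nitrile, or a pyridine ring in place of the phenyl, remains an open case. Going by these compounds, whether the shared core would tolerate an amide in place of its carboxylic acid in this assay also remains open.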